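Trifluoromethyl for fluoro on the aryl ring

A few compounds are considered here, and "the series" means these few. Any claim that something is new, unique, unknown or untested is made for them only; others in the source may bear on it.

In a functional assay on the whole organism (strain Swiss) with Mus musculus as the target, in the maximal electroshock model, with a stated time of 0.25 h, at a dose of 100 mg/kg by the intraperitoneal route (on this read-out lower numbers stand for a weaker effect and higher numbers for a stronger effect at the one dose given), the measured compounds give:
compound 1 `COc1cccc(N2CCN(C(=O)C(C)N3C(=O)CCC3=O)CC2)c1`: 25%
compound 2 `CCC(C(=O)N1CCN(c2cccc(F)c2)CC1)N1C(=O)CCC1=O`: 0%
compound 3 `CC(C(=O)N1CCN(c2cccc(F)c2)CC1)N1C(=O)CCC1=O`: 75%

Compound 3 stands highest of the three; nearest is compound 1, with a number 50 percentage points higher from compound 1 to compound 3 (beyond the scatter), furthest compound 2, with a number 75 percentage points higher from compound 2 to compound 3 (beyond the scatter). Compound 4 `CC(C(=O)N1CCN(c2cccc(C(F)(F)F)c2)CC1)N1C(=O)CCC1=O` differs from compound 3 only on the aryl ring: trifluoromethyl in place of fluoro on an aromatic carbon. Among the measured compounds shown here, of the measured steps only the one between compound 1 and compound 3 touches that ring, and it was large, so this position is sensitive in this assay. Nothing measured bears on trifluoromethyl itself. A change of moderate size is therefore expected, more likely downward than upward, with wide uncertainty: for compound 4 the estimate is 50%, between 10% and 90%, meaning a step of a number 25 percentage points lower from compound 3 to compound 4 (beyond the scatter).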

Compound 4, a percentage reported as activity, at one dose (the size of the read-out at that dose, not a potency): 50%
Compound 4: middle estimate and measured number agree at the digits printed; the measured number falls inside the stated range.
By their numbers in this assay, from the lowest: compound 2; then compound 1; then compound 4; then compound 3.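

In this assay, trifluoromethyl in place of fluoro gives a number 25 percentage points lower from compound 3 to compound 4 (beyond the scatter), so the larger group lowers the response without abolishing it. Trifluoromethyl in place of methoxy gives a number 25 percentage points higher from compound 1 to compound 4 (beyond the scatter), which ranks the three aryl groups on this core as fluoro, then trifluoromethyl, then methoxy, with each gap beyond the scatter. No available evidence accounts for this order.

A nitrile or an amine on this aromatic carbon could fall anywhere relative to that order. Going by these compounds, whether the added methyl of compound 2 would cost as much alongside trifluoromethyl also remains open.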